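Phenyl in Place of Thiophen-2-yl: an Expected Step

The source may report more compounds than this note shows. Statements on the series, on what has been measured and on what is new or still open speak of the compounds shown alone.

Two compounds have been measured in a functional assay on MGC-803 cells (Homo sapiens) for inhibition, read by MTT assay, with a stated time of 72 h; a lower number here means a stronger inhibitor, a higher number a weaker inhibitor:

compound 1, `Cc1ccc(CSc2nc3nc(C)cc(Nc4cc(-c5ccccc5)[nH]n4)n3n2)cc1`, gives 6960 nM
compound 2, `Cc1cc(Nc2cc(-c3cccs3)[nH]n2)n2nc(SCc3ccc(Br)cc3)nc2n1`, gives 3770 nM

Compound 2 shows the lower of the two numbers, but compound 1 lies within the usual scatter of it, so the two cannot be placed in an order. For the measured compounds named here, the two compounds also differ from each other in more than one place, so no single structural step between them can be read off.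

Compound 3, `Cc1cc(Nc2cc(-c3ccccc3)[nH]n2)n2nc(SCc3ccc(Br)cc3)nc2n1`, has not yet been measured. It differs from compound 2 in one place only: phenyl in place of thiophen-2-yl on an aromatic carbon. Going by the values given here, the only guide is that compound 1, which carries a phenyl at the same place, gives a number within the scatter of compound 2, though compound 1 differs elsewhere as well. On that basis the step of a 1.2-fold higher number from compound 2 to compound 3 (0.08 log units; within the scatter) is expected to be no larger than the scatter, with no clear direction. Compound 3 is therefore estimated to give 4500 nM, most likely between 2000 nM and 10000 nM.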

Compound 3, half-maximal inhibitory concentration: 1110 nM
Beside the measured number, compound 3's estimate is 4.1-fold (0.61 log units) above it, and the stated range ends above it.
By their numbers in this assay, from the lowest: compound 3; then compounds 2 and 1 (each within the scatter of the next).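

In this assay the ring at this place clearly matters: phenyl in place of thiophen-2-yl gives a 3.4-fold lower number from compound 2 to compound 3 (0.53 log units; beyond the scatter). This shows an effect that compound 1 and compound 2, which differ in more than one place, could not isolate. With phenyl held constant, a second change can also be read on its own, as bromo in place of methyl on an aromatic carbon gives a 6.3-fold lower number from compound 1 to compound 3 (0.80 log units; beyond the scatter) and shows that this other part of the molecule matters too. Nothing available here explains why either change lowers the number.

The compounds shown cover only phenyl and thiophen-2-yl at the first place, so they leave open how a furan-2-yl, a pyridine ring or a cyclohexyl ring would compare there. They also leave open whether chloro, methoxy or a carboxylic acid in place of the bromo would keep the lower number, and whether the effects of the two changes would hold in other combinations.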